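Replacing the cyclohexyl chain end in a cytotoxicity series

A few compounds are considered here, and "the series" means these few. Any claim that something is new, unique, unknown or untested is made for them only; others in the source may bear on it.

Three compounds sharing one core have been examined in an ADME assay on HOS cells (Homo sapiens) for cytotoxicity, read by luminescence and ATP content, with a stated time of 48 h; a lower number here means that less compound is tolerated, a higher number that more compound is tolerated. Compound 1 `CC(=O)OCCCc1cnc2c(c1)c(N)c(C(=O)NCc1ccc(F)cc1F)c(=O)n2O` returns only a limit, > 250000 nM. Compound 2 `Nc1c(C(=O)NCc2ccc(F)cc2F)c(=O)n(O)c2ncc(CCCC3CCCCC3)cc12` gives 27400 nM, the highest of the two actual numbers, and compound 3 `CN(C)CCCc1cnc2c(c1)c(N)c(C(=O)NCc1ccc(F)cc1F)c(=O)n2O` gives 5000 nM. The step of an at least 9.1-fold lower number from compound 1 to compound 2 (0.96 log units; beyond the scatter) and the step of a 5.5-fold lower number from compound 2 to compound 3 (0.74 log units; beyond the scatter) both point the same way: the more the chain end departs from the acetoxy group, the less compound is tolerated.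

Compound 4 `Nc1c(C(=O)NCc2ccc(F)cc2F)c(=O)n(O)c2ncc(CCC(=O)NCCO)cc12` has not yet been measured. Compared with compound 2 it carries (2-hydroxyethyl)carbamoyl in place of cyclohexylmethyl on a saturated chain carbon, two bonds along the chain from an aromatic carbon. The step of an at least 9.1-fold lower number from compound 1 to compound 2 (0.96 log units; beyond the scatter) is the one that bears most directly on this change, since it shows what happens when a cyclohexyl end replaces an uncharged oxygen-bearing end; compound 4 moves back in that direction, and compound 3 with its dimethylamino end shows the opposite kind of chain end gave the lowest number. Compound 4 is therefore expected to be tolerated more than compound 2, with a step of a 5.5-fold higher number from compound 2 to compound 4 (0.74 log units; beyond the scatter), and the result may again sit at the limit. Compound 4 is estimated at 150000 nM, within 40000 nM to 250000 nM.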

Compound 4, half-maximal cytotoxic concentration: > 250000 nM
Compound 4 was reported as a limit; the forecaster's own chance of this, stated with the estimate: 50%; at least 1.6-fold (0.22 log units) between middle value and limit.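

In this assay compound 4 gives > 250000 nM, which is a limit and not a number. The change from the cyclohexylmethyl end gives an at least 9.1-fold higher number from compound 2 to compound 4 (0.96 log units; beyond the scatter), and the change from the (dimethylamino)methyl end gives an at least 50-fold higher number from compound 3 to compound 4 (1.69 log units; beyond the scatter), so at this position an open chain end carrying an amide and a hydroxyl stays clear of both measured numbers. The acetoxy end of compound 1 is thus no longer the only chain end to reach the limit, though the step between compound 1 and compound 4 cannot be read, as both values are limits: the limit of > 250000 nM in this assay, at which 2 of the 4 values shown sit.

The compounds shown do not separate the amide of compound 4 from its terminal hydroxyl, and a chain ending in a carboxylic acid or a primary amide would bear on that question. They also leave open whether a longer chain with the same (2-hydroxyethyl)carbamoyl end, or a cyclic amine in place of the dimethylamino group, would stay at the limit or return a measured number.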